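The compounds below may be only part of what the source reports. "The series", "measured", "known", "first", "only" and "open" are said of these compounds alone.

Measured so far in a functional assay on SW480 cells (Homo sapiens) for antiproliferative activity, read by sulforhodamine B assay, with a stated time of 48 h; a lower number here means a stronger inhibitor, a higher number a weaker inhibitor:
compound 1 `COc1cc(C=C(C(=O)/C=C/c2cccc(OC)c2OC)C(=O)/C=C/c2cccc(OC)c2OC)cc(OC)c1O` gives 420 nM
compound 2 `COc1ccc(C=C(C(=O)/C=C/c2cccc(OC)c2OC)C(=O)/C=C/c2cccc(OC)c2OC)cc1O` gives 320 nM
compound 3 `COc1ccc(/C=C/C(=O)C(=Cc2cc(OC)c(O)c(OC)c2)C(=O)/C=C/c2ccc(OC)cc2OC)c(OC)c1` gives 850 nM

Compound 1 and compound 2 share one core; compound 2 carries the change (3-hydroxy-4-methoxyphenyl in place of 4-hydroxy-3,5-dimethoxyphenyl on a double-bonded chain carbon bound to a double-bonded chain carbon). That change gave a 1.3-fold lower number from compound 1 to compound 2 (0.12 log units; within the scatter). Compound 3 has the same atoms as compound 1 joined differently; how the two cores differ is not broken down here. Of the three numbers in this assay compound 3 gives the highest, and its gap to compound 1 as well as to compound 2 is beyond the scatter.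

Compound 4 `COc1ccc(/C=C/C(=O)C(=Cc2ccc(OC)c(O)c2)C(=O)/C=C/c2ccc(OC)cc2OC)c(OC)c1` is not yet measured. It differs from compound 3 by 3-hydroxy-4-methoxyphenyl in place of 4-hydroxy-3,5-dimethoxyphenyl on a double-bonded chain carbon bound to a double-bonded chain carbon, the same change that separates compound 1 from compound 2, at the same place. For the measured compounds named here, only one earlier instance of this change is available, so the expectation for compound 4 rests on it alone, together with compound 3 at 850 nM: the change is expected to leave the number nearly unmoved, about a 1.3-fold lower number from compound 3 to compound 4 (0.12 log units; within the scatter), because a 1.3-fold lower number from compound 1 to compound 2 (0.12 log units; within the scatter) was within the scatter. Compound 4 is therefore estimated at 650 nM in this assay, expected to lie between 300 nM and 1400 nM.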

Compound 4, half-maximal inhibitory concentration: 1370 nM
Compound 4: middle estimate off by 2.1-fold (0.32 log units), on the low side, within the range that was stated.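

In this assay, 3-hydroxy-4-methoxyphenyl in place of 4-hydroxy-3,5-dimethoxyphenyl on a double-bonded chain carbon gives a 1.6-fold higher number from compound 3 to compound 4 (0.21 log units; within the scatter). Set beside the earlier instance of the change, the two steps cannot be told apart, so the change carries from one core to the other with no measurable difference: the same change on two cores in this assay, a 1.3-fold lower number (0.12 log units; within the scatter) from compound 1 to compound 2 and a 1.6-fold higher number (0.21 log units; within the scatter) from compound 3 to compound 4, 2.1-fold (0.33 log units) apart, within the scatter of two such steps This shows only that the change stayed small on both cores; the opposite directions of the two steps cannot be read as a dependence on the core, and two pairs say nothing about whether the result extends to any further core in the series.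

The compounds shown have only these two hydroxy- and methoxy-bearing phenyl groups at this place, so it remains open how an amine or a carboxylic acid on that ring, or a longer chain in place of a methoxy group, would behave. On these data alone, whether the two steps would also stay this small in another cell line is equally open.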